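Methoxy to nitrile on the aryl ring of an isoxazole series

The compounds below may be only part of what the source reports. "The series", "measured", "known", "first", "only" and "open" are said of these compounds alone.

Three compounds that share one core were examined in a functional assay on Huh-7 cells (Homo sapiens) for cytotoxicity, with a stated time of 48 h; a higher number here means a weaker inhibitor, a lower number a stronger inhibitor. Compound 1 `COc1ccc(-c2cc(COC(Cc3cn(C4CCN(Cc5ccc([N+](=O)[O-])cc5)CC4)nn3)c3ccc(Br)cc3)on2)cc1` gives 2000 nM. Compound 2 `N#Cc1ccc(-c2cc(COC(Cc3cn(C4CCN(Cc5ccc([N+](=O)[O-])cc5)CC4)nn3)c3ccc(Br)cc3)on2)cc1` gives 5000 nM, and compound 3 `COc1cccc(-c2cc(COC(Cc3cn(C4CCN(Cc5ccc([N+](=O)[O-])cc5)CC4)nn3)c3ccc(Br)cc3)on2)c1` gives 5000 nM. The step of a 2.5-fold higher number from compound 1 to compound 2 (0.40 log units; beyond the scatter) arises from the change (cyano in place of methoxy on an aromatic carbon). The step of a 2.5-fold higher number from compound 1 to compound 3 (0.40 log units; beyond the scatter) arises from the rearrangement (3-methoxyphenyl in place of 4-methoxyphenyl on an aromatic carbon), in which the two compounds hold the same atoms joined differently. Between compound 2 and compound 3 the step of no change at the digits printed from compound 2 to compound 3 (within the scatter) shows nothing separable.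

Compound 4 `N#Cc1cccc(-c2cc(COC(Cc3cn(C4CCN(Cc5ccc([N+](=O)[O-])cc5)CC4)nn3)c3ccc(Br)cc3)on2)c1` has not yet been measured. It differs from compound 3 by cyano in place of methoxy on an aromatic carbon. Among the compounds with values here, this is the same kind of change as the one from compound 1 to compound 2, but not the same: in the earlier case the group sits para to a large group, while here it sits meta to a large group. The earlier instance produced a 2.5-fold higher number from compound 1 to compound 2 (0.40 log units; beyond the scatter), a modest weakening.

Within the data shown here, because a 2.5-fold higher number from compound 1 to compound 2 (0.40 log units; beyond the scatter) is the only precedent for exchanging methoxy for cyano here, the step from compound 3 to compound 4 in this assay is expected to be of similar size, a 2.0-fold higher number from compound 3 to compound 4 (0.30 log units; within the scatter), with some allowance for the different surroundings of the group. Compound 4 is therefore estimated at 10000 nM, with an expected range from 4000 nM to 25000 nM.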

Compound 4, half-maximal inhibitory concentration: 3000 nM
Compound 4: middle estimate off by 3.3-fold (0.52 log units), on the high side; measured number outside the range, below it.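

In this assay the exchange of methoxy for cyano does not carry over from one core to the other with the same size or sign: the same change on two cores in this assay, a 2.5-fold higher number (0.40 log units; beyond the scatter) from compound 1 to compound 2 and a 1.7-fold lower number (0.22 log units; within the scatter) from compound 3 to compound 4, 4.2-fold (0.62 log units) apart, beyond the scatter of two such steps

The later step, a 1.7-fold lower number from compound 3 to compound 4 (0.22 log units; within the scatter), is not separable from repeated measurement, so the comparison shows that the step seen on the 4-methoxyphenyl compound cannot be assumed for the 3-methoxyphenyl compound; it does not show that the exchange truly reverses there. Within the data shown here, the other two readings, a 1.7-fold lower number from compound 2 to compound 4 (0.22 log units; within the scatter) and a 1.5-fold higher number from compound 1 to compound 4 (0.18 log units; within the scatter), are also within the scatter, and with only one pair on each side the data cannot say whether the position of the group or something else separates the two results.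

Among these compounds, still open is whether other groups at these two places, such as a fluorine, a methyl or an amine, would behave like the exchange from compound 1 to compound 2 or like the one from compound 3 to compound 4. As far as these compounds go, the bromine and the nitro group are the same in all four compounds, so it is also open whether the exchange would behave alike with a chlorine or an amine in their place.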